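Furan-2-yl in Place of Phenyl: One Untested Step

A few compounds are considered here, and "the series" means these few. Any claim that something is new, unique, unknown or untested is made for them only; others in the source may bear on it.

Compound 1 `CCOC(=O)c1nn(-c2ccc([N+](=O)[O-])cc2)/c(=N/c2nc(-c3c(C)n(C)n(-c4ccccc4)c3=O)cs2)s1`: 8680 nM
Compound 2 `Cc1c(-c2csc(/N=C3\S/C(=C\c4ccccc4)C(=O)N3c3ccccc3)n2)c(=O)n(-c2ccccc2)n1C`: > 100000 nM

In a functional assay on A549 cells (Homo sapiens) for cytotoxicity, read by sulforhodamine B assay, with a stated time of 72 h (a higher number here means a weaker inhibitor, a lower number a stronger inhibitor), compound 1 gives 8680 nM. Compound 2 reaches only a limit of the assay, > 100000 nM. Compound 2 therefore stands at the limit of > 100000 nM in this assay, at which 1 of the 2 values shown sits, with no number of its own to compare against compound 1. Compound 3 `Cc1c(-c2csc(/N=C3\S/C(=C\c4ccco4)C(=O)N3c3ccccc3)n2)c(=O)n(-c2ccccc2)n1C` differs from compound 2 by furan-2-yl in place of phenyl on a double-bonded chain carbon bound to a double-bonded ring carbon. Among the measured compounds shown here, no measured pair of that kind is available here, so the step expected in this assay is a number no higher from compound 2 to compound 3 (the limit leaves the size open), none beyond the scatter. Compound 3 is estimated at 100000 nM, between 30000 nM and 300000 nM, and is expected most likely to return only a limit again.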

Compound 3, half-maximal inhibitory concentration: 13700 nM
Compound 3: middle estimate off by 7.3-fold (0.86 log units), on the high side, outside the stated range (below it).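

In this assay, furan-2-yl in place of phenyl on a double-bonded chain carbon bound to a double-bonded ring carbon gives an at least 7.2-fold lower number from compound 2 to compound 3 (0.86 log units; beyond the scatter), so the group on this carbon can bring the shared core from a limit to a measurable number. Compound 2 has only a limit, so the step has a floor but no known size: the limit of > 100000 nM in this assay, at which 1 of the 3 values shown sits.

From the compounds shown here alone, whether thiophen-2-yl or pyridin-2-yl on that carbon would act like furan-2-yl stays open. So does whether a methyl or an amine-bearing phenyl there would lower the number at all.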